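A few compounds are considered here, and "the series" means these few. Any claim that something is new, unique, unknown or untested is made for them only; others in the source may bear on it.

For the measured compounds named here, in a functional assay on A498 cells (Homo sapiens) for antiproliferative activity, read by sulforhodamine B assay, with a stated time of 48 h (a lower number here means a stronger inhibitor, a higher number a weaker inhibitor), compound 1 `O=C(NCCCNc1cc(-c2cn(-c3ccccc3)nc2-c2cccc(O)c2)ccn1)Nc1ccc(F)cc1` gives 1210 nM as the lower of the two numbers so far, while compound 2 `O=C(NCCCNc1cc(-c2cn(-c3ccccc3)nc2-c2cccc(O)c2)ccn1)Nc1cccc(C(F)(F)F)c1` gives 3170 nM as the higher one. Compound 3 `COc1cccc(-c2nn(-c3ccccc3)cc2-c2ccnc(NCCCNC(=O)Nc3ccc(F)cc3)c2)c1` differs from compound 1 at one spot: methyl in place of hydrogen on an oxygen on an aromatic ring in all, which means methyl in place of hydrogen on an oxygen on an aromatic ring, turning 3-hydroxyphenyl into 3-methoxyphenyl. Going by the values given here, the only measured step is a 2.6-fold higher number from compound 1 to compound 2 (0.42 log units; beyond the scatter) with 3-(trifluoromethyl)phenyl in place of 4-fluorophenyl on an amide-type nitrogen. That change lies elsewhere in the molecule, so it offers only a sense of size. Nothing measured compares hydroxy with methoxy, so in this assay no step beyond the scatter is firmly expected, with only a slight lean toward a higher number. The expected change is a 1.2-fold higher number from compound 1 to compound 3 (0.09 log units; within the scatter) by this estimate. Compound 3 is expected at 1500 nM within a range from 500 nM to 4500 nM in this estimate.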

Compound 3, half-maximal inhibitory concentration: 7370 nM
Estimate against measurement, compound 3: 4.9-fold (0.69 log units) below; the whole stated range lies below it.
By their numbers in this assay, from the lowest: compound 1; then compound 2; then compound 3.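

In this assay, placing a methyl on the oxygen of the 3-hydroxyphenyl group gives a 6.1-fold higher number from compound 1 to compound 3 (0.78 log units; beyond the scatter), a step beyond the scatter. For the compounds shown here, the earlier comparison concerned only a change on an amide-type nitrogen, so this is the first sign that this oxygen position also matters: replacing one hydrogen with a single methyl, which turns hydroxy into methoxy, weakens the antiproliferative effect. No supporting evidence is available to explain the loss, so its cause remains unknown.

Going by these compounds, it remains open whether other groups at this position would also weaken the effect, such as an amine in place of the hydroxy or an ethyl in place of the methyl on the oxygen. It is also unknown whether the methoxy would give a similar step alongside the 3-(trifluoromethyl)phenyl group of compound 2.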